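Methoxy in Place of Chloro on the Core of Compound 3

The compounds below may be only part of what the source reports. "The series", "measured", "known", "first", "only" and "open" are said of these compounds alone.

Three compounds have been measured in a functional assay on U-87MG ATCC cells for cytotoxicity against U-87 MG (Homo sapiens), read by MTT assay, with a stated time of 72 h; a higher number here means a weaker inhibitor, a lower number a stronger inhibitor:
compound 1, `O=C(Nc1nc2ccc(Cl)cc2s1)c1cn(-c2ccccc2)nc1-c1ccccc1`, 4980 nM
compound 2, `COc1ccc2nc(NC(=O)c3cn(-c4ccccc4)nc3-c3ccccc3)sc2c1`, 40600 nM
compound 3, `O=C(Nc1nc2ccc(Cl)cc2s1)c1cn(-c2ccccc2)nc1-c1ccc(Cl)cc1`, 5870 nM

Compound 4, `COc1ccc2nc(NC(=O)c3cn(-c4ccccc4)nc3-c3ccc(Cl)cc3)sc2c1`, has not yet been measured in this assay.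

Compound 3 differs from compound 1 by chloro in place of hydrogen on an aromatic carbon, and this step gives a 1.2-fold higher number from compound 1 to compound 3 (0.07 log units; within the scatter). Compound 4 carries the same core as compound 3 and differs from it by methoxy in place of chloro on an aromatic carbon.

The same change has already been made once among the measured compounds. Compound 2 differs from compound 1 by methoxy in place of chloro on an aromatic carbon, and in this assay that step gives an 8.2-fold higher number from compound 1 to compound 2 (0.91 log units; beyond the scatter). The place of the change in the pair compound 1 to compound 2 and in the pair compound 3 to compound 4 is described in the same words, so the two changes are of the same kind and on the same part of the molecule; only the group on the other ring, chloro in place of hydrogen, sets the two pairs apart, and that group itself made a step within the scatter.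

For the measured compounds named here, with only one earlier instance, the expectation rests on that single step. For compound 4 the step from compound 3 is estimated as a 7.7-fold higher number from compound 3 to compound 4 (0.88 log units; beyond the scatter), resting on the size of an 8.2-fold higher number from compound 1 to compound 2 (0.91 log units; beyond the scatter) in this assay. Compound 4 is therefore expected to give about 45000 nM in this assay, with a plausible range from 15000 nM to 120000 nM.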

Compound 4, half-maximal inhibitory concentration: 21200 nM
Compound 4: middle estimate off by 2.1-fold (0.33 log units), on the high side; low and high end bracket the measured number.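

In this assay, methoxy in place of chloro on the core of compound 3 gives a 3.6-fold higher number from compound 3 to compound 4 (0.56 log units; beyond the scatter), which is in the same direction as the earlier step on the core of compound 1 and does not differ from it beyond the scatter: the same change on two cores in this assay, an 8.2-fold higher number (0.91 log units; beyond the scatter) from compound 1 to compound 2 and a 3.6-fold higher number (0.56 log units; beyond the scatter) from compound 3 to compound 4, 2.3-fold (0.35 log units) apart, within the scatter of two such steps. The chloro in place of hydrogen on the other ring gives a 1.9-fold lower number from compound 2 to compound 4 (0.28 log units; within the scatter), a step within the scatter on the methoxy core as it was on the chloro core, and these two steps agree as well: the same change on two cores in this assay, a 1.2-fold higher number (0.07 log units; within the scatter) from compound 1 to compound 3 and a 1.9-fold lower number (0.28 log units; within the scatter) from compound 2 to compound 4, 2.3-fold (0.35 log units) apart, within the scatter of two such steps. Together, the four compounds show that in this small set each change carried from one core to the other, but this rests on only two pairs per change, with one group at each place, and it shows neither why the methoxy compounds give the higher numbers nor that the agreement would hold on any other core.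

The compounds shown leave open how an amine, a carboxylic acid or a longer chain would behave at the place held by chloro and methoxy on the fused system. They also leave open whether such groups on the other ring would carry between the two cores as the chloro did.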